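The source may report more compounds than this note shows. Statements on the series, on what has been measured and on what is new or still open speak of the compounds shown alone.

Measured in a functional assay on DU-145 cells (Homo sapiens) for cytotoxicity; on this read-out lower numbers stand for stronger inhibition and higher numbers for weaker inhibition:
- compound 1 `COc1ccc(Cn2cc(/C=N\NC(=O)c3c[nH]c4ccc(Br)cc34)c3cc(OC)ccc32)cc1`: 84400 nM
- compound 2 `COc1ccc2c(c1)c(/C=N\NC(=O)c1c[nH]c3ccc(Br)cc13)cn2Cc1ccc(Cl)cc1`: 57000 nM

Only these two compounds have been measured, and compound 2, at 57000 nM, cannot be separated from compound 1. Among the measured compounds shown here, the one measured step is a 1.5-fold lower number from compound 1 to compound 2 (0.17 log units; within the scatter), and it stays within the scatter.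

The next compound to be measured is compound 3 `COc1ccc2c(c1)c(/C=N\NC(=O)c1c[nH]c3ccccc13)cn2Cc1ccc(Cl)cc1`. It is reached from compound 2 by hydrogen in place of bromo on an aromatic carbon, which in words is hydrogen in place of bromo on an aromatic carbon.

For the measured compounds named here, no measured step touches the bromo. Going by the values given here, the only available step, a 1.5-fold lower number from compound 1 to compound 2 (0.17 log units; within the scatter), swaps methoxy for chloro at another place in the molecule, so it bears on this change only indirectly. It shows that one substitution on this scaffold left the number within the scatter, but it says nothing about the loss of the bromo. In this assay, therefore, no step beyond the scatter is expected, and no direction can be favoured.

The estimated step is a 1.1-fold higher number from compound 2 to compound 3 (0.02 log units; within the scatter), with wide uncertainty. Compound 3 is expected at about 60000 nM, with an estimated range of 22000 nM to 150000 nM.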

Compound 3, half-maximal inhibitory concentration: 50000 nM
Compound 3: the middle estimate sits 1.2-fold (0.08 log units) above what was measured, within the range that was stated.
By their numbers in this assay, from the lowest: compounds 3, 2 and 1 (each within the scatter of the next).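

In this assay, among the compounds shown here, the first change at this position, 5-bromo-1H-indol-3-yl to 1H-indol-3-yl, gives a 1.1-fold lower number from compound 2 to compound 3 (0.06 log units; within the scatter), so compound 2 and compound 3 cannot be told apart on this read-out. Compound 1 and compound 2 both carry the bromo and so could say nothing about it; compound 3 now shows that, with the chloro group in place elsewhere in the molecule, the number does not depend measurably on having a bromo rather than a hydrogen on this aromatic carbon. No supporting evidence is available to account for this result.

The compounds shown leave open whether a different group on this aromatic carbon, such as an amine or a carboxylic acid, would produce a step beyond the scatter from compound 3, which stands at 50000 nM. They also leave open whether hydrogen in place of bromo would give the same result in the methoxy-bearing compound 1, since this change is shown only with the chloro group present.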